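Oxamic acid and ester analogues in a rat whole-animal assay

The source may report more compounds than this note shows. Statements on the series, on what has been measured and on what is new or still open speak of the compounds shown alone.

Measured compounds:
compound 1, `CCOCCOC(=O)C(=O)Nc1nc(-c2cc(C)on2)cs1`: 1.3 mg/kg
compound 2, `CCOCCOC(=O)C(=O)Nc1nc(-c2cc(CO)on2)cs1`: 1.8 mg/kg
compound 3, `Cc1cc(-c2csc(NC(=O)C(=O)O)n2)on1`: 0.3 mg/kg

In a functional assay on the whole organism with Rattus norvegicus as the target (a higher number here means that more compound is needed for the effect, a lower number that less compound is needed), compound 1 gives 1.3 mg/kg. Compound 2 differs from compound 1 by hydroxy in place of hydrogen on a saturated chain carbon bound to an aromatic carbon. In this assay compound 2 gives 1.8 mg/kg; the step of a 1.4-fold higher number from compound 1 to compound 2 (0.14 log units; within the scatter). Compound 3 differs from compound 1 in more than one place, and the difference between the two cores is not broken down here. In this assay compound 3 gives 0.3 mg/kg, the lowest number of the three and beyond the scatter from both compound 1 and compound 2.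

Compound 4, `O=C(O)C(=O)Nc1nc(-c2cc(CO)no2)cs1`, has not yet been measured. It differs from compound 3 by hydroxy in place of hydrogen on a saturated chain carbon bound to an aromatic carbon, the same kind of change that turns compound 1 into compound 2. Because that earlier step, a 1.4-fold higher number from compound 1 to compound 2 (0.14 log units; within the scatter), stays within the scatter, a similarly small step is expected here, a 1.3-fold higher number from compound 3 to compound 4 (0.12 log units; within the scatter). Compound 4 is therefore estimated at 0.4 mg/kg in this assay, likely between 0.15 mg/kg and 1 mg/kg.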

Compound 4, dose for half-maximal effect: 0.007 mg/kg
Compound 4: middle estimate off by 57-fold (1.76 log units), on the high side, and the stated range ends above it.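

In this assay, the change from methyl to hydroxymethyl brought a 43-fold lower number from compound 3 to compound 4 (1.63 log units; beyond the scatter), and so it did not carry over from one core to the other with the same size: the same change on two cores in this assay, a 1.4-fold higher number (0.14 log units; within the scatter) from compound 1 to compound 2 and a 43-fold lower number (1.63 log units; beyond the scatter) from compound 3 to compound 4, 59-fold (1.77 log units) apart, beyond the scatter of two such steps

For these two pairs, then, the outcome of placing hydroxy on this saturated chain carbon depends on the core that carries it, and the earlier step on the core of compound 1 gave no reliable guide to the step on the core of compound 3. The data do not show which of the several differences between those two cores goes with the gap, and two pairs give no general rule for other cores in the series.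

The compounds shown leave open whether the large step belongs to hydroxy itself or would also appear with an amine or a methoxy group on that carbon. They also leave open whether a longer chain, such as hydroxyethyl, would keep it on the core of compound 4.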